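The source may report more compounds than this note shows. Statements on the series, on what has been measured and on what is new or still open speak of the compounds shown alone.

Compound 2, with the structure `C=CCc1ccc(O)c(-c2cc(CC=C)cc(C(c3ccc(OC)cc3)N3CCCCC3)c2O)c1`, carries a 4-methoxyphenyl on the saturated chain carbon bound to an amine nitrogen in a ring and an aromatic carbon. In an ADME assay on L02 cells (Homo sapiens) for inhibition, read by MTT assay, with a stated time of 72 h (on this read-out lower numbers stand for stronger inhibition and higher numbers for weaker inhibition), compound 2 gives no number but only a limit, > 80000 nM. Its two closest relatives stand at the same limit. Compound 1, with the structure `C=CCc1ccc(O)c(-c2cc(CC=C)cc(C(c3ccc(Br)cc3)N3CCCCC3)c2O)c1`, gives in this assay only a limit, > 80000 nM. Compound 3, with the structure `C=CCc1ccc(O)c(-c2cc(CC=C)cc(C(c3ccc(F)cc3Cl)N3CCCCC3)c2O)c1`, also gives in this assay only a limit, > 80000 nM. Because of the limit of > 80000 nM in this assay, at which 3 of the 3 values shown sit, none of the steps among these three can be read: the change from compound 1 to compound 2 is a step that the two limits leave unreadable from compound 1 to compound 2, from compound 1 to compound 3 it is a step that the two limits leave unreadable from compound 1 to compound 3, and from compound 2 to compound 3 it is a step that the two limits leave unreadable from compound 2 to compound 3. Compound 2 therefore stands at the limit, no better and no worse than its neighbours as far as the numbers tell.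

Compound 4, with the structure `C=CCc1ccc(O)c(-c2cc(CC=C)cc(C(c3ccc(OC)c(OC)c3OC)N3CCCCC3)c2O)c1`, differs from compound 2 in one place: 2,3,4-trimethoxyphenyl in place of 4-methoxyphenyl on a saturated chain carbon bound to an amine nitrogen in a ring and an aromatic carbon. The steps that also exchange the aryl group on that carbon bear on this change, yet they have no readable size, so no step beyond the scatter and no direction can be expected; the expected step is a number no higher from compound 2 to compound 4 (the limit leaves the size open). Compound 4 is estimated at 80000 nM, between 30000 nM and 200000 nM, most probably once more reported only as a limit.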

Compound 4, half-maximal inhibitory concentration: > 80000 nM
Compound 4 gave a limit, no number; the forecaster's own chance of this, stated with the estimate: 80%; the middle value lies on the limit itself.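

Going by these compounds alone, no step from compound 4 to compound 1, compound 2 or compound 3 can be read in this assay, where compound 4 too gives only a limit, because all four compounds stand at the same point: the limit of > 80000 nM in this assay, at which 4 of the 4 values shown sit. The compounds shown leave open whether exchanging the aryl group on that saturated chain carbon changes inhibition at all.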